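A few compounds are considered here, and "the series" means these few. Any claim that something is new, unique, unknown or untested is made for them only; others in the source may bear on it.

Measured so far:
Compound 1 `COc1ccc(/C=C/C(=O)c2c(OC)cc(O)c(CC=C(C)C)c2O)cc1`: 32400 nM
Compound 2 `COc1cc(/C=C/C(=O)c2c(OC)cc(O)c(CC=C(C)C)c2O)ccc1O`: 21700 nM
Compound 3 `COc1cc(O)c(CC=C(C)C)c(O)c1C(=O)/C=C/c1ccc(O)c(O)c1`: 15200 nM

All three were tested in a functional assay on HepG2 cells (Homo sapiens) for inhibition, read by MTT assay, with a stated time of 72 h; on this read-out lower numbers stand for stronger inhibition and higher numbers for weaker inhibition. Compound 3 shares the low end of these numbers with compound 2, as the measured 1.4-fold lower number from compound 2 to compound 3 (0.15 log units; within the scatter) shows. Compound 1 alone stands apart, with a 2.1-fold lower number from compound 1 to compound 3 (0.33 log units; beyond the scatter).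

The next compound is compound 4 `COc1ccccc1/C=C/C(=O)c1c(OC)cc(O)c(CC=C(C)C)c1O`, and the change from compound 3 is 2-methoxyphenyl in place of 3,4-dihydroxyphenyl on a double-bonded chain carbon bound to a double-bonded chain carbon. Of the measured compounds, compound 1 resembles it most, since it also has a methoxyphenyl group with no hydroxyl on that ring. For the measured compounds named here, the steps that bear on this change are small: a 1.5-fold lower number from compound 1 to compound 2 (0.17 log units; within the scatter), and the modest 2.1-fold lower number from compound 1 to compound 3 (0.33 log units; beyond the scatter). Going by the values given here, no measured compound carries the 2-methoxyphenyl group itself, so this comparison is only a rough guide. A modest move towards a higher number is therefore expected, close to the size of the scatter.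

The estimated step is a 1.8-fold higher number from compound 3 to compound 4 (0.27 log units; within the scatter). Compound 4 is estimated at 28000 nM, with an expected range of 13000 nM to 60000 nM.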

Compound 4, half-maximal inhibitory concentration: 14600 nM
Estimate against measurement, compound 4: 1.9-fold (0.28 log units) above, within the range that was stated.
By their numbers in this assay, from the lowest: compounds 4, 3, 2 and 1 (each within the scatter of the next, the first and the last beyond it).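

In this assay, the 2-methoxyphenyl group has no hydrogen-bond donors, yet the step is a 1.0-fold lower number from compound 3 to compound 4 (0.02 log units; within the scatter) and the step from the ring of compound 2 is a 1.5-fold lower number from compound 2 to compound 4 (0.17 log units; within the scatter), so a hydroxyl on this ring is not needed to reach the low end of these numbers. The earlier compounds shown here left hydroxyl-free compound 1 alone at the high end, but a 2.2-fold lower number from compound 1 to compound 4 (0.35 log units; beyond the scatter) shows that two hydroxyl-free methoxyphenyl rings can differ beyond the scatter, with 2-methoxyphenyl giving the lower number. No other measurement is available to explain this difference.

The compounds shown leave open how this place responds to a ring carrying an amine, a carboxylic acid or a fluorine. They also leave open whether 3-methoxyphenyl would fall with compound 4 or with compound 1.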